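Benzyl ring swap on a sulfonylguanidine core

The compounds below may be only part of what the source reports. "The series", "measured", "known", "first", "only" and "open" are said of these compounds alone.

Of the compounds shown here, three sharing one sulfonylguanidine core have been tested in an ADME assay on microsomes from liver (Homo sapiens) for metabolic stability, read by LC-MS, using NADPH, tested at 5 uM; on this read-out lower numbers stand for a shorter-lived compound and higher numbers for a longer-lived compound. Compound 2 `Cc1cc(S(=O)(=O)/N=C(\N)n2nccc2-c2ccccc2)c(SCc2cccc(Cl)c2)cc1Cl` gives 0.309 h in this assay. Compound 3 `Cc1cccc(CSc2cc(Cl)c(C)cc2S(=O)(=O)/N=C(\N)n2nc(C)cc2-c2ccccc2)c1` gives 0.214 h, and compound 1 `Cc1ccc(CSc2cc(Cl)c(C)cc2S(=O)(=O)/N=C(\N)n2nc(C)cc2-c2ccccc2)cc1` gives 0.176 h; all three numbers lie within the scatter of one another. Going by the values given here, the only single-point step among them, a 1.2-fold higher number from compound 1 to compound 3 (0.08 log units; within the scatter), moves one ring substituent and changes nothing beyond the scatter. Compound 4 `Cc1cc(S(=O)(=O)/N=C(\N)n2nccc2-c2ccccc2)c(SCc2ccc(C(F)(F)F)cc2)cc1Cl` is compound 2 with 4-(trifluoromethyl)phenyl in place of 3-chlorophenyl on a saturated chain carbon bound to a sulfur. Among the compounds with values here, the one measured step bearing on this kind of benzyl ring change was flat, so no step beyond the scatter is expected in this assay, an estimate of a 1.0-fold lower number from compound 2 to compound 4 (0.01 log units; within the scatter). Compound 4 is therefore expected to give about 0.3 h, between 0.15 h and 0.6 h.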

Compound 4, half-life: 0.176 h
Compound 4: middle estimate off by 1.7-fold (0.23 log units), on the high side; measured number inside the range.
By their numbers in this assay, from the lowest: compounds 1, 4, 3 and 2 (each within the scatter of the next).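

Replacing 3-chlorophenyl with 4-(trifluoromethyl)phenyl on a saturated chain carbon bound to a sulfur gives, in this assay, a 1.8-fold lower number from compound 2 to compound 4 (0.24 log units; within the scatter). Unlike the earlier step, this change replaces the ring substituent itself as well as moving it, and it still stays within the scatter. Nothing available here accounts for this step.

As far as these compounds go, it remains open whether a benzyl ring carrying an amine or a carboxylic acid would also stay within the scatter in this assay. The same question stands for a longer chain between the sulfur and the ring.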